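Hydroxy for vinyl on two benzoxazole-bearing sulfonamides

This account rests on a few compounds, and the source may have more. Where it says the series, first, only, none or still open, it means among the compounds named here.

Compound 1 `C=Cc1ccc(S(=O)(=O)Nc2ccc3oc(-c4ccccc4)nc3c2)cc1` and compound 2 `C=Cc1ccc(S(=O)(=O)Nc2ccc(-c3nc4ccccc4o3)cc2)cc1` share the same atoms joined differently; the difference between the two cores is not broken down here. In an assay on cells for inhibition of HSP60/HSP10 (Homo sapiens), with a stated time of 60 min (a higher number here means a weaker inhibitor, a lower number a stronger inhibitor), compound 1 gives > 100000 nM, which is a limit of the assay. In this assay compound 2 likewise gives > 100000 nM, a limit. Compound 3 `O=S(=O)(Nc1ccc2oc(-c3ccccc3)nc2c1)c1ccc(O)cc1` carries hydroxy in place of vinyl on an aromatic carbon and gives 88000 nM in this assay, so the step of an at least 1.1-fold lower number from compound 1 to compound 3 (0.05 log units; that floor lies within the scatter) is known only from one side, since compound 1 sits at the limit of > 100000 nM in this assay, at which 2 of the 3 values shown sit. Compound 4 `O=S(=O)(Nc1ccc(-c2nc3ccccc3o2)cc1)c1ccc(O)cc1` carries the same change on the core of compound 2, (hydroxy in place of vinyl on an aromatic carbon). The step from compound 2 to compound 4 is expected to be a number no higher from compound 2 to compound 4 (the limit leaves the size open), resting on the step from compound 1 to compound 3 alone. Compound 4 is therefore estimated at 100000 nM, between 45000 nM and 300000 nM.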

Compound 4, half-maximal inhibitory concentration: 78000 nM
Beside the measured number, compound 4's estimate is 1.3-fold (0.11 log units) above it; measured number inside the range.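

In this assay, hydroxy in place of vinyl on the core of compound 2 gives an at least 1.2-fold lower number from compound 2 to compound 4 (0.10 log units; that floor lies within the scatter), so on this second core too the change from 4-vinylphenyl to 4-hydroxyphenyl leads from a limit to a measured number. Set beside each other, the two steps have no known size: the same change on two cores in this assay, an at least 1.1-fold lower number (0.05 log units; that floor lies within the scatter) from compound 1 to compound 3 and an at least 1.2-fold lower number (0.10 log units; that floor lies within the scatter) from compound 2 to compound 4; the limit leaves it open whether they differ. The series thus shows that both cores respond alike in this one respect, but it does not show that the change brings a gain beyond the scatter on either core, or that it carries over by the same amount.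

The compounds shown leave open whether an amine or a carboxylic acid in the same place would give a lower number on either core. They also leave open how a methoxy group there would compare with hydroxy.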